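This account rests on a few compounds, and the source may have more. Where it says the series, first, only, none or still open, it means among the compounds named here.

Compound 3 `CC(C)CNC(=O)c1ccc(C#Cc2cccc(F)c2)cn1` gives 58.2% in a functional assay on HEK293 cells for positive allosteric modulation of metabotropic glutamate receptor 5 (Rattus norvegicus), read by fluorescence and calcium flux (on this read-out lower numbers stand for smaller maximal responses and higher numbers for larger maximal responses), the lowest of the three numbers at hand. Within the data shown here, compound 1 `C[C@@H](NC(=O)c1ccc(C#Cc2ccccc2F)cn1)C(C)(C)O` gives 60%, within the scatter of compound 3, while compound 2 `C[C@H](NC(=O)c1ccc(C#Cc2cccc(F)c2)cn1)C(C)(C)C` gives 70.8%, the only value beyond it. Among the measured compounds shown here, the one step between close neighbours, a number 12.6 percentage points lower from compound 2 to compound 3 (beyond the scatter), shows that exchanging the group on the amide-type nitrogen can move the maximal response by a modest amount. Compound 4 `CC(C)(CO)NC(=O)c1ccc(C#Cc2cccc(F)c2)cn1` differs from compound 3 by 1-(hydroxymethyl)-1-methylethyl in place of isobutyl on an amide-type nitrogen. For the measured compounds named here, no measured step covers this exchange, but compound 1, whose group on the amide-type nitrogen likewise holds a hydrogen-bond donor, lies close to compound 3. Compound 4 is therefore expected to show a step of a number 1.8 percentage points higher from compound 3 to compound 4 (within the scatter), within the scatter. Compound 4 is estimated at 60%, within a range of 45% to 75%.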

Compound 4, largest response reached (reported as efficacy), in percent of the reference or control that the assay uses: 60.9%
Compound 4: the middle estimate sits 0.9 percentage points below what was measured, within the range that was stated.
By their numbers in this assay, from the lowest: compounds 3, 1, 4 and 2 (each within the scatter of the next, the first and the last beyond it).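

In this assay, putting 1-(hydroxymethyl)-1-methylethyl in place of isobutyl on an amide-type nitrogen leaves the maximal response unchanged within the scatter (a number 2.7 percentage points higher from compound 3 to compound 4 (within the scatter)), so this position tolerates a group carrying a hydrogen-bond donor. Compound 4 also stays within the scatter of the 1,2,2-trimethylpropyl compound (a number 9.9 percentage points lower from compound 2 to compound 4 (within the scatter)), a pair that isobutyl did not match. Nothing available explains either result. As far as these compounds go, whether an amine or a carboxylic acid in place of the hydroxyl would keep this response remains open. So does the effect of a longer chain on that nitrogen.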